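Three Analogues at the Assay Limit and a Fourth

The compounds below may be only part of what the source reports. "The series", "measured", "known", "first", "only" and "open" are said of these compounds alone.

Measured so far in a functional assay on A549 cells (Homo sapiens) for antiproliferative activity, read by MTT assay, with a stated time of 48 h; a higher number here means a weaker inhibitor, a lower number a stronger inhibitor:
Compound 1, `CCOc1ccccc1-n1nncc1CN1C(=O)C2(C(C#N)=C(N)Oc3c2c2nc4ccccc4nc2c2ccccc32)c2ccccc21`, gives > 50000 nM, which is a limit of the assay and not a number.
Compound 2, `N#CC1=C(N)Oc2c(c3nc4ccccc4nc3c3ccccc23)C12C(=O)N(Cc1cnnn1-c1ccc([N+](=O)[O-])cc1)c1ccccc12`, gives > 50000 nM, likewise only a limit.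
Compound 3, `CCOc1ccccc1-n1nncc1CN1C(=O)C2(C(C#N)=C(N)Oc3c(N)cc4nc5ccccc5nc4c32)c2ccccc21`, gives > 50000 nM, again only a limit.

Compound 2 differs from compound 1 by 4-nitrophenyl in place of 2-ethoxyphenyl on an aromatic nitrogen. The resulting step, a step that the two limits leave unreadable from compound 1 to compound 2, cannot be read because of the limit of > 50000 nM in this assay, at which 3 of the 3 values shown sit. How the core of compound 1 and the core of compound 3 differ is not broken down here.

Compound 4, `N#CC1=C(N)Oc2c(N)cc3nc4ccccc4nc3c2C12C(=O)N(Cc1cnnn1-c1ccc([N+](=O)[O-])cc1)c1ccccc12`, has not yet been measured in this assay. It differs from compound 3 by 4-nitrophenyl in place of 2-ethoxyphenyl on an aromatic nitrogen, the same change as from compound 1 to compound 2. Since that earlier step stayed unreadable between two limits, the step that the limit leaves unreadable from compound 3 to compound 4 is only an expectation without a measured anchor. Compound 4 is therefore expected to give about 80000 nM in this assay, most likely reported again as a limit.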

Compound 4, half-maximal inhibitory concentration: > 50000 nM
Compound 4 was reported as a limit (the forecaster's own chance of this, stated with the estimate: 90%); the middle value is on the limit's open side.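

No step can be read from compound 3 to compound 4, because both values are limits and not numbers: the limit of > 50000 nM in this assay, at which 4 of the 4 values shown sit.

The compounds shown leave open whether swapping 2-ethoxyphenyl for 4-nitrophenyl changes activity in this assay at all.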